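This account rests on a few compounds, and the source may have more. Where it says the series, first, only, none or still open, it means among the compounds named here.

Measured so far:

Compound 1 `CC[C@H]1OC(=O)[C@H](C)[C@@H](O[C@H]2C[C@@](C)(OC)[C@@H](O)[C@H](C)O2)[C@H](C)[C@@H](O[C@@H]2O[C@H](C)C[C@H](N(C)C)[C@H]2O)[C@](C)(O)C[C@@H](C)CN(CCCNC(C)=O)[C@H](C)[C@@H](O)[C@]1(C)O` in a physicochemical assay for lipophilicity, read by HPLC, measured as chromatographic lipophilicity, at pH 7.4 (on this read-out higher numbers stand for higher lipophilicity and lower numbers for lower lipophilicity), gives 2.06.
Compound 2 `CCCCC(=O)NCCCO[C@@H]1[C@@H](C)N(C)C[C@H](C)C[C@@](C)(O)[C@H](O[C@@H]2O[C@H](C)C[C@H](N(C)C)[C@H]2O)[C@@H](C)[C@H](O[C@H]2C[C@@](C)(OC)[C@@H](O)[C@H](C)O2)[C@@H](C)C(=O)O[C@H](CC)[C@@]1(C)O` in this assay gives 3.74.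
Compound 3 `CCCCC(=O)NCCCN1C[C@H](C)C[C@@](C)(O)[C@H](O[C@@H]2O[C@H](C)C[C@H](N(C)C)[C@H]2O)[C@@H](C)[C@H](O[C@H]2C[C@@](C)(OC)[C@@H](O)[C@H](C)O2)[C@@H](C)C(=O)O[C@H](CC)[C@@](C)(O)[C@H](O)[C@H]1C` in this assay gives 2.72.

Compound 2 sits highest of the three in this assay; compound 3 stands nearest to it and compound 1 furthest, both gaps beyond the scatter. Compound 3 and compound 1 differ in one place, namely (hydrogen in place of propyl on a saturated chain carbon bound to a carbonyl carbon), and this change gives a number 0.66 log units lower from compound 3 to compound 1 (beyond the scatter), a modest drop and beyond the scatter.

Compound 4 `CC[C@H]1OC(=O)[C@H](C)[C@@H](O[C@H]2C[C@@](C)(OC)[C@@H](O)[C@H](C)O2)[C@H](C)[C@@H](O[C@@H]2O[C@H](C)C[C@H](N(C)C)[C@H]2O)[C@](C)(O)C[C@@H](C)CN(C)[C@H](C)[C@@H](OCCCNC(C)=O)[C@]1(C)O` is not yet measured. Within the data shown here, it is related to compound 2 by hydrogen in place of propyl on a saturated chain carbon bound to a carbonyl carbon, which is the same change as the one from compound 3 to compound 1: the "place" of both reads the same word for word. Among the measured compounds shown here, the cores of compound 2 and compound 3 differ in more than one place, and the difference between the two cores is not broken down here; what is known is only that compound 2 gives 3.74 and compound 3 gives 2.72 in this assay.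

For the measured compounds named here, with the single worked instance as the only guide, a drop of about the same size is expected from compound 2 to compound 4 in this assay, that is a number 0.66 log units lower from compound 2 to compound 4 (beyond the scatter), resting on the step of a number 0.66 log units lower from compound 3 to compound 1 (beyond the scatter) seen between compound 3 and compound 1. The wider interval allows for the two cores not being the same. Compound 4 is therefore estimated at 3.08 in this assay, expected to lie between 2.65 and 3.5.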

Compound 4, distribution coefficient: 2.41
Compound 4: middle estimate off by 0.67 log units, on the high side; the measured number lies below the stated range.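

In this assay, hydrogen in place of propyl on a saturated chain carbon bound to a carbonyl carbon gives a number 1.33 log units lower from compound 2 to compound 4 (beyond the scatter) as a large step, and a number 0.66 log units lower from compound 3 to compound 1 (beyond the scatter) as a modest one. The direction of the change therefore carries over between these two cores, but its size does not carry over as a fixed increment, and two pairs cannot show how either size would hold on any further core. No data at hand explain why the same change gives steps of different size on the two cores.

Still open is whether the trend in this series extends to other groups at the same place on a saturated chain carbon bound to a carbonyl carbon, for instance a longer chain such as hexyl, an amine or a carboxylic acid, as the only pairs shown here exchange propyl for hydrogen. Also open, as far as these compounds go, is whether a further core would give a step closer to the large one or to the modest one, or a step outside both.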